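This account rests on a few compounds, and the source may have more. Where it says the series, first, only, none or still open, it means among the compounds named here.

Compound 1 `CCCn1cnc2ncnc(N)c21` reaches only a limit in an assay on CHO cells for displacement of a labelled ligand from adenosine receptor A1 (Homo sapiens) (on this read-out higher numbers stand for weaker inhibition and lower numbers for stronger inhibition), giving > 100000 nM. Compound 2 `CCC(C)n1cnc2ncnc(N)c21` likewise returns only a limit in this assay, > 100000 nM. The step that the two limits leave unreadable from compound 1 to compound 2 is thus unreadable in size and direction. For the measured compounds named here, compound 3 `Nc1ncnc2c1ncn2C1CCC1` is the one member with a number, giving 8700 nM in this assay. Going by the values given here, the change to compound 4 `Nc1ncnc2ncn(CCO)c12` is hydroxy in place of methyl on a saturated chain carbon, two bonds along the chain from an aromatic nitrogen; no measured step covers a hydroxy group, and the only comparison starting from compound 1 is the pair of limits (the limit of > 100000 nM in this assay, at which 2 of the 3 values shown sit), which carries no size. Compound 4 is therefore expected to remain near the limit, with the step that the limit leaves unreadable from compound 1 to compound 4 taken as uncertain. The estimate for compound 4 is 150000 nM, within 30000 nM to 600000 nM.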

Compound 4, inhibition constant: > 100000 nM
Compound 4: only a limit was reported (the forecaster's own chance of this, stated with the estimate: 70%); the middle value does not contradict the limit.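

Compound 4 returns only a limit in this assay, > 100000 nM, so its steps from compound 1 and compound 2 cannot be read. Going by these compounds, the size and direction of the change on placing hydroxy in place of methyl remain open.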